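Methoxy in Place of Cyano: Estimating Compound 4

The source may report more compounds than this note shows. Statements on the series, on what has been measured and on what is new or still open speak of the compounds shown alone.

Compound 1 `COc1ccc(C2=NO[C@]3(C2)C(=O)O[C@@H]2[C@H]3CC[C@H](C)[C@]3(O)C=CC(=O)[C@@]23C)cc1` and compound 2 `C[C@H]1CC[C@@H]2[C@@H](OC(=O)[C@]23CC(c2ccc(C#N)cc2)=NO3)[C@]2(C)C(=O)C=C[C@@]12O` share one core. In a physicochemical assay for lipophilicity (on this read-out lower numbers stand for lower lipophilicity and higher numbers for higher lipophilicity), compound 1 gives 1.47 and compound 2 gives 1.17. The change from compound 2 to compound 1 is methoxy in place of cyano on an aromatic carbon and it produced a number 0.30 log units higher from compound 2 to compound 1 (within the scatter). Compound 3 `C[C@H]1CC[C@@H]2[C@@H](OC(=O)[C@]23CC(c2ccc(C#N)cc2)N(c2ccccc2)O3)[C@]2(C)C(=O)C=C[C@@]12O` is built on another core; how its core differs from that of compound 2 is not broken down here. In this assay compound 3 gives 2.94. Compound 4 `COc1ccc(C2C[C@@]3(ON2c2ccccc2)C(=O)O[C@@H]2[C@H]3CC[C@H](C)[C@]3(O)C=CC(=O)[C@@]23C)cc1` has not been measured yet. It differs from compound 3 by methoxy in place of cyano on an aromatic carbon, the same change as between compound 2 and compound 1, at the same place. Because the earlier change gave a number 0.30 log units higher from compound 2 to compound 1 (within the scatter), a step of the same size is expected, namely a number 0.30 log units higher from compound 3 to compound 4 (within the scatter). Compound 4 is therefore estimated at 3.24, most likely between 2.85 and 3.65.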

Compound 4, partition coefficient: 3.25
Compound 4: the middle estimate sits 0.01 log units below what was measured; the measured number falls inside the stated range.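

In this assay the same swap of cyano for methoxy gives a number 0.31 log units higher from compound 3 to compound 4 (beyond the scatter) and so closely matches the earlier a number 0.30 log units higher from compound 2 to compound 1 (within the scatter) on the other core. This shows that in these two pairs the step kept its size from one core to the other, but two pairs cannot show that it would do so on any further core. Nothing measured here accounts for the match.

The compounds shown carry only cyano or methoxy at this place on the aromatic ring. From the compounds shown here alone, whether an amine or a carboxylic acid there would also give a step of matching size on both cores remains open.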